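A few compounds are considered here, and "the series" means these few. Any claim that something is new, unique, unknown or untested is made for them only; others in the source may bear on it.

Working notes on the series. Compound 1 `CC(Cn1cc[n+](C)c1/C=N/O)NS(=O)(=O)C(F)(F)F` gives -0.82 in a physicochemical assay for lipophilicity; a higher number here means a more lipophilic compound, a lower number a more polar compound. Compound 2 `CCC(Cn1cc[n+](C)c1/C=N/O)NS(=O)(=O)C(F)(F)F` gives -0.42 in this assay; the step of a number 0.40 log units higher from compound 1 to compound 2 (beyond the scatter) belongs to methyl in place of hydrogen on a saturated chain carbon, two bonds along the chain from a sulfonamide nitrogen. Compound 3 `CN(CCCn1cc[n+](C)c1/C=N/O)S(=O)(=O)c1ccccc1` gives -1.59 in this assay, the lowest of the three numbers, with gaps to compound 1 and compound 2 that both lie beyond the scatter. The difference between the core of compound 1 and the core of compound 3 is not broken down here.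

Compound 4 `CCN(CCCn1cc[n+](C)c1/C=N/O)S(=O)(=O)c1ccccc1` is not yet measured in this assay. It differs from compound 3 by methyl in place of hydrogen on a saturated chain carbon bound to a sulfonamide nitrogen. This is the same kind of change as from compound 1 to compound 2, but the place differs: there the carbon is two bonds along the chain from a sulfonamide nitrogen, here it is bound to the sulfonamide nitrogen. Going by the values given here, a step of a number 0.39 log units higher from compound 3 to compound 4 (beyond the scatter) is expected, resting on the single measured case a number 0.40 log units higher from compound 1 to compound 2 (beyond the scatter). Compound 4 is expected to give about -1.2, estimated between -1.6 and -0.8.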

Compound 4, distribution coefficient: -1.27
For compound 4 the middle estimate is 0.07 log units above the measured one; the range from low to high includes it.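

The new step (a number 0.32 log units higher from compound 3 to compound 4 (beyond the scatter)) runs the same way as the earlier one (a number 0.40 log units higher from compound 1 to compound 2 (beyond the scatter)) in this assay, so on both cores methyl in place of hydrogen on a saturated chain carbon goes with a higher number. These are only two cases, and they differ in core and in place at once, so they cannot separate the one from the other or set a rule for further cores. No measurement shown gives a reason for either step.

From the compounds shown here alone, the same change at the same place on both cores remains open. So does whether a longer chain, such as propyl, or an amine at this place would follow the same direction.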